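The source may report more compounds than this note shows. Statements on the series, on what has been measured and on what is new or still open speak of the compounds shown alone.

Of the compounds shown here, three sharing one core have been measured in an ADME assay on L6 cells (Rattus norvegicus) for cytotoxicity, read by resazurin assay, with a stated time of 72 h; on this read-out higher numbers stand for weaker inhibition and lower numbers for stronger inhibition. In it compound 1 (`CCc1ccc(C(=O)NC(=O)c2ccccc2O)cc1`) gives 70 ug/mL, compound 2 (`Cc1ccc(C(=O)NC(=O)c2ccccc2O)cc1`) gives 46 ug/mL and compound 3 (`CC(C)(C)c1ccc(C(=O)NC(=O)c2ccccc2O)cc1`) gives 2.3 ug/mL, the lowest number of the three. The next compound, compound 4 (`O=C(NC(=O)c1ccccc1O)c1ccc(-c2ccccc2)cc1`), carries phenyl in place of tert-butyl on an aromatic carbon.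

Two large steps bear on this change, a 30-fold lower number from compound 1 to compound 3 (1.48 log units; beyond the scatter) and a 20-fold lower number from compound 2 to compound 3 (1.30 log units; beyond the scatter), and both end at tert-butyl. The remaining step, a 1.5-fold lower number from compound 1 to compound 2 (0.18 log units; within the scatter), stays within the scatter, so methyl and ethyl are not told apart in this assay. None of these steps brings in a ring, and the data do not show how phenyl compares with tert-butyl. The low number of compound 3, 2.3 ug/mL, is therefore the nearest guide, with some room for a return towards the higher numbers of the smaller groups. The expected step is small, a 1.7-fold higher number from compound 3 to compound 4 (0.24 log units; within the scatter), and it is not expected to go beyond the scatter. Compound 4 is estimated at 4 ug/mL, with an expected range from 1.2 ug/mL to 20 ug/mL.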

Compound 4, half-maximal inhibitory concentration: > 100 ug/mL
Compound 4: a limit, no number; the forecaster's own chance of this, stated with the estimate: 5%; at least 25-fold (1.39 log units) between middle value and limit.
By their numbers in this assay, from the lowest: compound 3; then compounds 2 and 1 (each within the scatter of the next). At a limit, above all of these: compound 4.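

In this assay compound 4 is recorded only as a limit of the assay, not as a number: the limit of > 100 ug/mL in this assay, at which 1 of the 4 values shown sits. Even so, the change from tert-butyl to phenyl on this aromatic carbon gives a large step, an at least 43-fold higher number from compound 3 to compound 4 (1.63 log units; beyond the scatter), so the low number of compound 3 does not carry over to phenyl, and the number does not keep falling as the group on this carbon gains heavy atoms, with compound 4 going against any such trend. Against the smaller groups the picture is less sharp: an at least 2.1-fold higher number from compound 2 to compound 4 (0.33 log units; beyond the scatter) already lies beyond the scatter and places compound 4 above the methyl compound, whereas an at least 1.4-fold higher number from compound 1 to compound 4 (0.15 log units; that floor lies within the scatter) has a floor within the scatter, so that step alone does not separate phenyl from ethyl.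

From the compounds shown here alone, how far above the limit compound 4 truly lies stays open, and so does whether the low number of compound 3 belongs to tert-butyl alone or would also appear with isopropyl or a longer chain at this place. Going by these compounds, how an amine or a carboxylic acid on this aromatic carbon would read in this assay also remains open.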